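The source may hold more compounds than are shown below. What is called first, only, known or untested is meant among the compounds shown, and "the series" means these compounds.

Measured in a functional assay on HT-1080 cells (Homo sapiens) for cytotoxicity, read by MTT assay, with a stated time of 72 h; on this read-out lower numbers stand for stronger inhibition and higher numbers for weaker inhibition:

- compound 1 (`COc1ccc(/C=C2\CCC/C(=C\c3ccccc3Cl)C2=O)cc1OC`): 6800 nM
- compound 2 (`COc1ccccc1/C=C1\CCC/C(=C\c2ccc(OC)c(OC)c2)C1=O`): 8100 nM
- compound 3 (`COc1ccc(/C=C2\CCC/C(=C\c3ccc(O)cc3)C2=O)cc1OC`): 16800 nM

Compound 3 has the highest number of the three, and both of its steps lie beyond the scatter: a 2.5-fold higher number from compound 1 to compound 3 (0.39 log units; beyond the scatter) and a 2.1-fold higher number from compound 2 to compound 3 (0.32 log units; beyond the scatter). Going to compound 4 (`COc1ccc(/C=C2\CCC/C(=C\c3cccc(Cl)c3Cl)C2=O)cc1OC`) makes the change (2,3-dichlorophenyl in place of 4-hydroxyphenyl on a double-bonded chain carbon bound to a double-bonded ring carbon), on a double-bonded chain carbon bound to a double-bonded ring carbon.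

The closest evidence is a 2.5-fold higher number from compound 1 to compound 3 (0.39 log units; beyond the scatter), which has the 2-chlorophenyl group leaving and the 4-hydroxyphenyl group entering at that same place. Read in reverse, it points to a modest move towards a lower number. The step of a 1.2-fold higher number from compound 1 to compound 2 (0.08 log units; within the scatter) adds only that methoxy in place of chloro made no change beyond the scatter. Going by the values given here, no measured compound carries the 2,3-dichlorophenyl group, so the size of the step remains uncertain.

The expected step is a 2.6-fold lower number from compound 3 to compound 4 (0.41 log units; beyond the scatter), a modest gain in inhibition. For compound 4 the estimated value is 6500 nM, with an expected range of 2500 nM to 14000 nM.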

Compound 4, half-maximal inhibitory concentration: 8800 nM
Estimate against measurement, compound 4: 1.4-fold (0.13 log units) below; low and high end bracket the measured number.
By their numbers in this assay, from the lowest: compounds 1, 2, 4 and 3 (each within the scatter of the next, the first and the last beyond it).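

In this assay, a 1.9-fold lower number from compound 3 to compound 4 (0.28 log units; within the scatter) places the 2,3-dichlorophenyl group within the scatter of the 4-hydroxyphenyl group at this place, so the earlier step beyond the scatter does not recur in full for this replacement. Adding chloro on an aromatic carbon, a 1.3-fold higher number from compound 1 to compound 4 (0.11 log units; within the scatter), and replacing 2-methoxyphenyl with 2,3-dichlorophenyl, a 1.1-fold higher number from compound 2 to compound 4 (0.04 log units; within the scatter), also stay within the scatter, leaving compound 1, compound 2 and compound 4 unseparated at this place. No supporting data bear on the origin of these steps.

The aryl groups shown at this place carry only chloro, methoxy or hydroxy substituents, so the effect of an amine or a carboxylic acid there remains open. On these data alone, whether these steps hold when the other side of the shared core is changed also remains open.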